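Nitrophenyl benzoate analogue: expected potency in the series

The source may hold more compounds than are shown below. What is called first, only, known or untested is meant among the compounds shown, and "the series" means these compounds.

Within the data shown here, the three measured members share one core. Compound 2 `C=C(C(=O)c1ccc(OC)cc1)C(OC(=O)c1ccccc1)c1ccc(Cl)cc1Cl` gives 79200 nM in a functional assay on A549 cells (Homo sapiens) for inhibition, read by XTT assay, with a stated time of 48 h; a lower number here means a stronger inhibitor, a higher number a weaker inhibitor. Compound 3 `C=C(C(=O)c1ccc(OC)cc1)C(OC(=O)c1ccccc1)C(CC)CC` gives 35200 nM in this assay, the second highest of the three numbers; compound 1 `C=C(C(=O)c1ccc(OC)cc1)C(OC(C)=O)c1ccc([N+](=O)[O-])cc1` gives 21300 nM in this assay, within the scatter of compound 3, while compound 2 lies beyond it. Compound 4 `C=C(C(=O)c1ccc(OC)cc1)C(OC(=O)c1ccccc1)c1ccc([N+](=O)[O-])cc1` has not been measured. It differs from compound 3 in one place: 4-nitrophenyl in place of pentan-3-yl on a saturated chain carbon bound to a double-bonded chain carbon and an oxygen next to a carbonyl group.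

Among the measured compounds shown here, one measured step bears on this change: a 2.3-fold lower number from compound 2 to compound 3 (0.35 log units; beyond the scatter), a move from an aryl group to pentan-3-yl in the same place that lowered the number modestly. The step to compound 4 runs in the opposite sense, pentan-3-yl to an aryl group, though with 4-nitrophenyl rather than 2,4-dichlorophenyl, so its size is not fixed by that single step. Compound 1, which also carries 4-nitrophenyl in this place, sits within the scatter of compound 3, which argues against a large shift in either direction. Compound 4 is therefore expected to show a step of a 1.0-fold lower number from compound 3 to compound 4 (0.00 log units; within the scatter), within or barely beyond the scatter. The estimate for compound 4 in this assay is 35000 nM, with a range from 12000 nM to 100000 nM.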

Compound 4, half-maximal inhibitory concentration: 66600 nM
The estimate for compound 4 lay 1.9-fold (0.28 log units) below the measured number; the measured number falls inside the stated range.
By their numbers in this assay, from the lowest: compounds 1, 3, 4 and 2 (each within the scatter of the next, the first and the last beyond it).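

In this assay, among these compounds, 4-nitrophenyl in place of pentan-3-yl on the saturated chain carbon gives a 1.9-fold higher number from compound 3 to compound 4 (0.28 log units; within the scatter), and 4-nitrophenyl in place of 2,4-dichlorophenyl gives a 1.2-fold lower number from compound 2 to compound 4 (0.08 log units; within the scatter), so neither exchange separates the groups at this place, and a 2.3-fold lower number from compound 2 to compound 3 (0.35 log units; beyond the scatter) remains the only step there beyond the scatter. Among the compounds shown here, the clearer reading comes from the other place, the carbonyl carbon, where phenyl in place of methyl gives a 3.1-fold higher number from compound 1 to compound 4 (0.50 log units; beyond the scatter), the first step that shows this carbonyl substituent can shift the number beyond the scatter while 4-nitrophenyl stays fixed. No measurement at hand accounts for any of these readings.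

On these data alone, the step from methyl to phenyl rests on a single pair, so whether it holds with 2,4-dichlorophenyl or pentan-3-yl on the saturated chain carbon stays open. Also open, as far as these compounds go, is how a longer chain in place of phenyl on the carbonyl carbon, or an amine in place of 4-nitrophenyl on the saturated chain carbon, would read in this assay.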